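One More Methoxy on Compound 2

The compounds below may be only part of what the source reports. "The series", "measured", "known", "first", "only" and "open" are said of these compounds alone.

- compound 1 `COc1cccc(/C=C/C(=O)Oc2ccc(C(C)=O)cc2)c1`: > 2780000 nM (a limit)
- compound 2 `COc1ccc(/C=C/C(=O)Oc2ccc(C(C)=O)cc2)cc1`: > 3270000 nM (a limit)

In an ADME assay on HepG2 2.2.15 cells (Homo sapiens) for cytotoxicity, read by MTT assay (on this read-out higher numbers stand for lower toxicity in this test and lower numbers for higher toxicity in this test), compound 2 stands at > 3270000 nM, which is a limit of the assay and not a number. Compound 1 gives > 2780000 nM, and this too is a limit. Within the data shown here, the two compounds therefore give no measured step, and neither has an exact value.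

Compound 3 `COc1ccc(/C=C/C(=O)Oc2ccc(C(C)=O)cc2)cc1OC` differs from compound 2 by one change: methoxy in place of hydrogen on an aromatic carbon. The new methoxy sits ortho to a methoxy group and meta to a large group.

Among the measured compounds shown here, with no measured step as a guide, no shift beyond the usual scatter is expected in this assay, in either direction. The expected value for compound 3 is 2800000 nM, with an estimated range of 1000000 nM to 4500000 nM.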

Compound 3, half-maximal cytotoxic concentration: > 2610000 nM
Compound 3 gave a limit, no number (the forecaster's own chance of this, stated with the estimate: 65%); the middle value lies beyond the limit too.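

Among these compounds, compound 1, compound 2 and compound 3 each give only a limit in this assay, so no step from compound 1 or compound 2 to compound 3 can be read. Going by these compounds, whether the extra methoxy shifts the read-out at all, and by how much, stays open.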